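The source may report more compounds than this note shows. Statements on the series, on what has been measured and on what is new or still open speak of the compounds shown alone.

Compound 1 `COc1ccc(CS(=O)(=O)/C=C/c2ccc(F)cc2)cc1` is the simplest of the set. In a functional assay on DU-145 cells (Homo sapiens) for antiproliferative activity, read by trypan blue exclusion (on this read-out higher numbers stand for weaker inhibition and lower numbers for stronger inhibition), compound 1 gives 1250 nM. Compound 2 `COc1ccc(CS(=O)(=O)/C=C/c2ccc(F)cc2OC)cc1` differs from it by one change, (methoxy in place of hydrogen on an aromatic carbon), and in this assay compound 2 gives 10000 nM, so that an 8.0-fold higher number from compound 1 to compound 2 (0.90 log units; beyond the scatter). Compound 3 `COc1ccc(CS(=O)(=O)/C=C/c2ccc(OC)cc2OC)cc1` carries a methoxy in place of the fluoro on an aromatic carbon. For compound 3 this assay reports only a limit, > 20000 nM, which is the limit of > 20000 nM in this assay, at which 1 of the 3 values shown sits. The step of an at least 2.0-fold higher number from compound 2 to compound 3 (0.30 log units; that floor lies within the scatter). How the core of compound 3 differs from that of compound 1 is not broken down here.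

Compound 4 `COc1ccc(CS(=O)(=O)/C=C/c2ccc(OC)c(OC)c2OC)cc1` has not yet been measured. It differs from compound 3 by methoxy in place of hydrogen on an aromatic carbon. This is the same kind of change as from compound 1 to compound 2, but the surroundings differ: in compound 2 the new methoxy sits ortho to a large group and meta to a fluoro group, whereas in compound 4 it sits ortho to two methoxy groups and meta to a large group. Compound 3 itself is reported only as the limit > 20000 nM. Compound 4 is therefore expected to give about 30000 nM, an estimated step that the limit leaves unreadable from compound 3 to compound 4, most likely again reported as a limit rather than a number.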

Compound 4, half-maximal inhibitory concentration: > 20000 nM
Compound 4: no number, only a limit; the forecaster's own chance of this, stated with the estimate: 80%; the middle value does not contradict the limit.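

Compound 3 and compound 4 both stand only as limits in this assay, so no step between them can be read, and the size of the added methoxy's effect stays unknown: the limit of > 20000 nM in this assay, at which 2 of the 4 values shown sit.

The compounds shown leave open whether this methoxy in place of hydrogen changes the inhibition at all, and in which direction.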